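Replacing 3,5-dimethoxyphenyl with 3-aminophenyl in compound 3

The compounds below may be only part of what the source reports. "The series", "measured", "known", "first", "only" and "open" are said of these compounds alone.

Measured so far in a functional assay on HCT-116 cells (Homo sapiens) for cytotoxicity, read by MTT assay, with a stated time of 72 h; a lower number here means a stronger inhibitor, a higher number a weaker inhibitor:
Compound 1 `Nc1cccc(Nc2nc3ccccc3nc2S(=O)(=O)c2ccccc2)c1`: 1540 nM
Compound 2 `COc1ccc(Nc2nc3ccccc3nc2S(=O)(=O)c2ccc(C)cc2)cc1`: > 50000 nM (a limit)
Compound 3 `COc1cc(Nc2nc3ccccc3nc2S(=O)(=O)c2ccc(C)cc2)cc(OC)c1`: > 50000 nM (a limit)

Compound 3 stands at > 50000 nM, which is a limit of the assay and not a number. Compound 2 stands at the same kind of limit, > 50000 nM. The series thus holds (the limit of > 50000 nM in this assay, at which 2 of the 3 values shown sit).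

Compound 4 `Cc1ccc(S(=O)(=O)c2nc3ccccc3nc2Nc2cccc(N)c2)cc1` has not yet been measured. It differs from compound 3 as follows: 3-aminophenyl in place of 3,5-dimethoxyphenyl on a nitrogen on an aromatic ring. Among the measured compounds shown here, the only measured step between neighbours, a step that the two limits leave unreadable from compound 2 to compound 3, offers no size to carry over. The closest guide is compound 1, which also bears 3-aminophenyl, although its core is not identical, and which gives 1540 nM in this assay. A real gain in inhibition is therefore expected, of a size that remains uncertain. The expected change is an at least 16-fold lower number from compound 3 to compound 4 (1.22 log units; beyond the scatter), towards a stronger inhibitor. For compound 4 the estimated value is 3000 nM, with an expected range of 800 nM to 15000 nM.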

Compound 4, half-maximal inhibitory concentration: 2390 nM
Compound 4: middle estimate off by 1.3-fold (0.10 log units), on the high side; measured number inside the range.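

In this assay, 3-aminophenyl on the nitrogen gives a readable value where both methoxy-bearing groups did not, with an at least 20-fold lower number from compound 3 to compound 4 (1.32 log units; beyond the scatter) and an at least 20-fold lower number from compound 2 to compound 4 (1.32 log units; beyond the scatter). These sizes are only lower bounds and the step between compound 2 and compound 3 cannot be read, because both of those compounds sit at a limit of the assay: the limit of > 50000 nM in this assay, at which 2 of the 4 values shown sit. Methyl in place of hydrogen on an aromatic carbon stays within the usual scatter, with a 1.6-fold higher number from compound 1 to compound 4 (0.19 log units; within the scatter), so the readable value holds for 3-aminophenyl both with and without that methyl.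

The compounds shown do not tell whether the amine itself or its place on the ring carries the gain. Going by these compounds, how 4-aminophenyl, 3-hydroxyphenyl or an acetylated amine would read in this assay remains open.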